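Replacing Bromomethylphenyl with Dimethylphenyl on the Shared Core

This account rests on a few compounds, and the source may have more. Where it says the series, first, only, none or still open, it means among the compounds named here.

Of the compounds shown here, two of a shared core have been measured in a functional assay on KBVIN cells (Homo sapiens) for antiproliferative activity, read by sulforhodamine B assay, with a stated time of 3 days; a lower number here means that less compound is needed, a higher number that more compound is needed for the effect. Compound 1 `CCC1=C(O)c2c(oc(-c3ccc(C(F)(F)F)cc3)cc2=O)C(CC)(CC)C1=O` gives 10.4 uM. Compound 2 `CCC1=C(O)c2c(oc(-c3ccc(CBr)cc3)cc2=O)C(CC)(CC)C1=O` gives 27.9 uM, the highest of the two numbers; its nearest neighbour is compound 1, separated by the step of a 2.7-fold higher number from compound 1 to compound 2 (0.43 log units; beyond the scatter). Compound 3 `CCC1=C(O)c2c(oc(-c3cccc(C)c3C)cc2=O)C(CC)(CC)C1=O` has not yet been measured. It differs from compound 2 in one place: 2,3-dimethylphenyl in place of 4-(bromomethyl)phenyl on an aromatic carbon. Within the data shown here, the only measured step, a 2.7-fold higher number from compound 1 to compound 2 (0.43 log units; beyond the scatter), concerns the same place on the core but a different exchange, so it bears on compound 3 only by showing that a change there moves the number modestly. Among the measured compounds shown here, no measured pair shows what the 2,3-dimethylphenyl group does. A modest step is therefore expected, without a firm direction; since compound 2 holds the higher of the two numbers, a drift back toward compound 1 is as plausible as a further rise, and the range must stay wide. Compound 3 is expected to give about 16 uM, within a range from 5 uM to 50 uM. The expected step is a 1.7-fold lower number from compound 2 to compound 3 (0.24 log units; within the scatter).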

Compound 3, concentration for half-maximal effect: 0.85 uM
The estimate for compound 3 lay 19-fold (1.27 log units) above the measured number; measured number below the stated range.
By their numbers in this assay, from the lowest: compound 3; then compound 1; then compound 2.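

In this assay, putting 2,3-dimethylphenyl in place of 4-(bromomethyl)phenyl gives a 33-fold lower number from compound 2 to compound 3 (1.52 log units; beyond the scatter) and so shows that this position on the shared core, on the aromatic carbon next to the ring oxygen, can move the number much further than the step of a 2.7-fold higher number from compound 1 to compound 2 (0.43 log units; beyond the scatter) had indicated. The leaving and entering groups have the same count of heavy atoms and each holds one six-membered aromatic ring of carbon only, so those counts do not separate them; the two groups differ in the bromine and in the placing of their substituents, as their names show. Compound 3 at 0.85 uM also has a lower printed number than compound 1 at 10.4 uM and so holds the lowest of the three.

The compounds shown do not separate the effect of losing the 4-(bromomethyl) substituent from that of gaining the two methyl groups, and they leave open where 2-methylphenyl, 3-methylphenyl, unsubstituted phenyl or a phenyl ring carrying an amine or a carboxylic acid would stand. No measurement given here accounts for the size of this step.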